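A few compounds are considered here, and "the series" means these few. Any claim that something is new, unique, unknown or untested is made for them only; others in the source may bear on it.

Measured in a functional assay on HCT-116 cells (Homo sapiens) for cytotoxicity, read by MTT assay, with a stated time of 72 h; on this read-out lower numbers stand for stronger inhibition and higher numbers for weaker inhibition:
- compound 1 `Cc1ccc(S(=O)(=O)n2cc(COC3=C/C(=N\c4ccccc4)c4ccccc4C3=O)nn2)cc1`: 5370 nM
- compound 2 `Cc1ccc(S(=O)(=O)n2cc(COC3=C/C(=N\c4ccc(I)cc4)c4ccccc4C3=O)nn2)cc1`: > 16300 nM
- compound 3 `Cc1ccc(S(=O)(=O)n2cc(COC3=C/C(=N\c4ccc(F)cc4)c4ccccc4C3=O)nn2)cc1`: 5750 nM

Compound 2 gives no number, only a limit of the assay, > 16300 nM. Within the data shown here, it is the one compound of the three that stands at the limit of > 16300 nM in this assay, at which 1 of the 3 values shown sits. Its true position is therefore open on one side, and any step leaving it is bounded rather than exact.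

Compound 4 `COc1ccc(/N=C2\C=C(OCc3cn(S(=O)(=O)c4ccc(C)cc4)nn3)C(=O)c3ccccc32)cc1` has not yet been measured. It differs from compound 2 by methoxy in place of iodo on an aromatic carbon, para to a large group: methoxy in place of iodo on an aromatic carbon.

Among the measured compounds shown here, three measured steps bear on this change. Putting iodo in place of hydrogen gave an at least 3.0-fold higher number from compound 1 to compound 2 (0.48 log units; beyond the scatter). Replacing iodo with fluoro gave an at least 2.8-fold lower number from compound 2 to compound 3 (0.45 log units; beyond the scatter), the closest parallel to the change in question. Fluoro in place of hydrogen gave a 1.1-fold higher number from compound 1 to compound 3 (0.03 log units; within the scatter). For the measured compounds named here, both compounds without iodo thus sit well clear of the limit, although no methoxy compound has been measured in this assay. On that basis, a move towards lower numbers of a size similar to the fluoro step is expected, with real uncertainty for a group not yet tested.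

The expected step is an at least 2.5-fold lower number from compound 2 to compound 4 (0.39 log units; beyond the scatter).

For compound 4 the estimate is 6500 nM, with an expected range of 2500 nM to 16000 nM.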

Compound 4, half-maximal inhibitory concentration: 7430 nM
Beside the measured number, compound 4's estimate is 1.1-fold (0.06 log units) below it; the measured number falls inside the stated range.
By their numbers in this assay, from the lowest: compounds 1, 3 and 4 (each within the scatter of the next). At a limit, above all of these: compound 2.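

In this assay, the change from 4-iodophenyl to 4-methoxyphenyl gives an at least 2.1-fold lower number from compound 2 to compound 4 (0.34 log units; beyond the scatter), which shows that a group other than fluoro at this position also stays clear of the limit, and that this holds for a group of two heavy atoms carrying a hydrogen-bond acceptor. Methoxy cannot be told apart from either hydrogen or fluoro here, with a 1.4-fold higher number from compound 1 to compound 4 (0.14 log units; within the scatter) and a 1.3-fold higher number from compound 3 to compound 4 (0.11 log units; within the scatter), so compounds 1, 3 and 4 form one group despite the different substituents. Among the four compounds, only compound 2, with iodo, stands apart, and what it gives is a limit rather than a number: the limit of > 16300 nM in this assay, at which 1 of the 4 values shown sits.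

On these data alone, how far compound 2 truly lies from the other three stays open, so the step to compound 4 has a bound but no exact size. The compounds shown also leave open whether chloro or bromo at this position would behave like fluoro or like iodo, and whether an amine or a carboxylic acid there would stay with compounds 1, 3 and 4.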